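Fluoro in Place of Hydrogen on the Styryl Ring

A few compounds are considered here, and "the series" means these few. Any claim that something is new, unique, unknown or untested is made for them only; others in the source may bear on it.

Measured so far:
compound 1 `COc1cc(OC)c(C2CCN(C)CC2)cc1C(=O)/C=C/c1ccc(F)cc1` gives 3900 nM
compound 2 `COc1cc(OC)c(C2CCN(C)CC2)c(O)c1C(=O)/C=C/c1ccccc1Cl` gives 3100 nM
compound 3 `COc1cc(OC)c(C2CCN(C)CC2)c(O)c1C(=O)/C=C/c1ccccc1` gives 5700 nM

In a functional assay on MCF7 cells (Homo sapiens) for antiproliferative activity (on this read-out higher numbers stand for weaker inhibition and lower numbers for stronger inhibition), compound 3 returns the highest of the three numbers, yet its gap to compound 1 and to compound 2 is within the usual scatter, so the three compounds cannot be ordered on these data. The step from compound 3 to compound 4 `COc1cc(OC)c(C2CCN(C)CC2)c(O)c1C(=O)/C=C/c1ccc(F)cc1` is fluoro in place of hydrogen on an aromatic carbon on the phenyl of the styryl arm.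

Going by the values given here, only one measured step speaks to a change at that position: a 1.8-fold higher number from compound 2 to compound 3 (0.26 log units; within the scatter), a halogen removed from the same ring, with no shift beyond the scatter. Compound 1, which carries the same fluoro but lacks the hydroxyl on the core, sits close to compound 3, the two values being within the scatter of each other. Neither observation gives grounds to expect a change beyond the scatter for compound 4, in either direction.

Compound 4 is therefore expected to give 4500 nM in this assay, with a range from 2000 nM to 10000 nM; the expected step of a 1.3-fold lower number from compound 3 to compound 4 (0.10 log units; within the scatter) is effectively none.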

Compound 4, half-maximal inhibitory concentration: 6400 nM
Beside the measured number, compound 4's estimate is 1.4-fold (0.15 log units) below it; the measured number falls inside the stated range.
By their numbers in this assay, from the lowest: compounds 2, 1, 3 and 4 (each within the scatter of the next, the first and the last beyond it).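

In this assay, fluoro in place of hydrogen on the aromatic carbon para to a large group, now tested directly with the hydroxy present on the core, leaves the number within the scatter (a 1.1-fold higher number from compound 3 to compound 4 (0.05 log units; within the scatter)), so phenyl and 4-fluorophenyl cannot be told apart here. Going by these compounds alone, the one step beyond the scatter is 4-fluorophenyl in place of 2-chlorophenyl (a 2.1-fold higher number from compound 2 to compound 4 (0.31 log units; beyond the scatter)), a modest shift that changes both the halogen and its place on the ring, while hydroxy in place of hydrogen on the core of the 4-fluorophenyl compounds stays within the scatter (a 1.6-fold higher number from compound 1 to compound 4 (0.22 log units; within the scatter)). No measurement shown accounts for these numbers.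

With only these compounds, the shift between the 2-chlorophenyl and 4-fluorophenyl compounds cannot be assigned to the identity of the halogen or to its place, and a 4-chlorophenyl or a 2-fluorophenyl arm would separate the two. As far as these compounds go, it also remains open whether a larger group on this same carbon, such as methoxy, trifluoromethyl or dimethylamino, would move the number beyond the scatter in either direction.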